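This account rests on a few compounds, and the source may have more. Where it says the series, first, only, none or still open, it means among the compounds named here.

Compound 1, with structure `COc1ccc(/C=C\c2cc(OC)c(OC)c(OC)c2)cc1OCc1ccc(CN[C@H](C(=O)O)[C@H](C)O)cc1`, is the starting point here. In a functional assay on B16-F10 cells (Mus musculus) for antiproliferative activity, read by CCK-8 assay, with a stated time of 48 h (on this read-out higher numbers stand for weaker inhibition and lower numbers for stronger inhibition), compound 1 gives only a limit of the assay, > 10000 nM, not a number. Two close relatives share this position. Compound 2, with structure `COc1ccc(/C=C\c2cc(OC)c(OC)c(OC)c2)cc1OCc1ccc(CN2C[C@H](O)C[C@@H]2C(=O)O)cc1`, is likewise reported in this assay only as the limit > 10000 nM. Compound 3, with structure `COc1ccc(/C=C\c2cc(OC)c(OC)c(OC)c2)cc1OCc1ccc(CN2CC[C@@H](C(=O)O)C2)cc1`, also sits at the limit > 10000 nM in this assay. Because all three values rest at the limit of > 10000 nM in this assay, at which 3 of the 3 values shown sit, the steps between them carry no readable size: a step that the two limits leave unreadable from compound 1 to compound 2, a step that the two limits leave unreadable from compound 1 to compound 3 and a step that the two limits leave unreadable from compound 2 to compound 3 each stay unreadable.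

The unmeasured compound 4, with structure `COc1ccc(/C=C\c2cc(OC)c(OC)c(OC)c2)cc1OCc1ccc(CN2CC[C@H](O)C2)cc1`, differs from compound 1 as follows: 3-hydroxypyrrolidin-1-yl in place of (1-carboxy-2-hydroxypropyl)amino on a saturated chain carbon bound to an aromatic carbon. The three measured steps each swap one carboxy-bearing group for another and all end at the same limit, so they give no guide to the size or direction of a step whose entering group carries no carboxy. The change in compound 4 is therefore of a kind not covered by the measured compounds, and the expectation for it rests on the structural change alone. Compound 4 is estimated at 2000 nM in this assay, with a wide range from 100 nM to 20000 nM. The expected step of an at least 5.0-fold lower number from compound 1 to compound 4 (0.69 log units; beyond the scatter) is thus towards stronger inhibition, though with little certainty.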

Compound 4, half-maximal inhibitory concentration: > 10000 nM
Compound 4: only a limit was reported; the forecaster's own chance of this, stated with the estimate: 45%; at least 5.0-fold (0.69 log units) between middle value and limit.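

In this assay compound 4 gives > 10000 nM, which is a limit and not a number. The steps to compound 4 from compound 1, compound 2 and compound 3 cannot be read, because all four compounds rest at the same limit: the limit of > 10000 nM in this assay, at which 4 of the 4 values shown sit.

The compounds shown leave open how strongly each one inhibits these cells and whether their differing groups change that inhibition at all.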